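Replacing the phenyl on the amine nitrogen with ethyl

This account rests on a few compounds, and the source may have more. Where it says the series, first, only, none or still open, it means among the compounds named here.

The three measured compounds share one core. Compound 1 is `Brc1ccc(NC2=NCCC3(CCCCC3)S2)cc1`, compound 2 is `COc1ccc(NC2=NCCC3(CCCCC3)S2)cc1` and compound 3 is `c1ccc(NC2=NCCC3(CCCCC3)S2)cc1`. In a physicochemical assay for lipophilicity, measured as octanol-water partition, at pH 7.4 (a lower number here means a more polar compound, a higher number a more lipophilic compound), compound 1 gives 2.53, compound 2 gives 0.8 and compound 3 gives 1.02. Compound 3 stands second highest of the three; its gap to compound 2 lies within the scatter, while a number 1.51 log units lower from compound 1 to compound 3 (beyond the scatter) lies well beyond it, as does a number 1.73 log units lower from compound 1 to compound 2 (beyond the scatter). Compound 4, `CCNC1=NCCC2(CCCCC2)S1`, differs from compound 3 in one place: ethyl in place of phenyl on an amine nitrogen. Going by the values given here, none of the measured steps touches the amine nitrogen; all of them alter a substituent on the phenyl that now leaves, so they describe only how much that ring's substitution can move this assay, not the loss of the ring itself. The account therefore rests on compound 3 alone, and a step downward is expected, estimated as a number 1.32 log units lower from compound 3 to compound 4 (beyond the scatter). Compound 4 is expected to give -0.3, within -1.3 to 0.7.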

Compound 4, distribution coefficient: 1.38
Compound 4: middle estimate off by 1.68 log units, on the low side, and the stated range ends below it.
By their numbers in this assay, from the lowest: compounds 2 and 3 (each within the scatter of the next); then compound 4; then compound 1.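

Ethyl in place of phenyl on the amine nitrogen gives a number 0.36 log units higher from compound 3 to compound 4 (beyond the scatter) in this assay, so removing this ring does not lower the number, and the number moves upward instead. Going by these compounds alone, the earlier steps changed only substituents on the phenyl, whereas this one is the first reading at the amine nitrogen itself, and it shows that this position tolerates a smaller group with no ring without any fall in the number. No measurement bears on why the step runs in this direction.

A single pair cannot show whether the number follows the length of the chain on this nitrogen or simply the absence of the ring. A methyl group, a propyl chain, a cyclohexyl ring or a benzyl group in the same place would separate these readings.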